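Compound 2 to compound 3: one group exchanged

The source may hold more compounds than are shown below. What is called first, only, known or untested is meant among the compounds shown, and "the series" means these compounds.

Values so far in an ADME assay on a cell-free system (plasma, Mus musculus, strain CD-1) for metabolic stability, read by LC-MS, tested at 1 uM (on this read-out lower numbers stand for a shorter-lived compound and higher numbers for a longer-lived compound), are these
- compound 1 (`COc1cccc(C)c1NC(=O)c1ccc(NC(=O)CCc2nc3ccccc3c(=O)[nH]2)cc1`) gives 4.5 h
- compound 2 (`Cn1nc(-c2ccc(NC(=O)CCc3nc4ccccc4c(=O)[nH]3)cc2)c2ccccc21`) gives > 16.6 h

Compound 2 stands at a limit of the assay and not at a number (> 16.6 h). Compound 3 (`O=C(CCc1nc2ccccc2c(=O)[nH]1)Nc1ccc(-c2nnc(-c3ccccc3)o2)cc1`) carries 5-phenyl-1,3,4-oxadiazol-2-yl in place of 1-methyl-1H-indazol-3-yl on an aromatic carbon, para to a large group (5-phenyl-1,3,4-oxadiazol-2-yl in place of 1-methyl-1H-indazol-3-yl on an aromatic carbon). Resting on compound 2, itself only a limit (> 16.6 h), no change beyond the scatter is expected in this assay (an at least 1.1-fold lower number from compound 2 to compound 3 (0.04 log units; that floor lies within the scatter)). Compound 3 is estimated at 15 h (expected range 7 h to 30 h).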

Compound 3, half-life: 2.03 h
Compound 3: the middle estimate sits 7.4-fold (0.87 log units) above what was measured, and the stated range ends above it.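

In this assay, the group on this aromatic carbon, para to a large group, clearly matters: 5-phenyl-1,3,4-oxadiazol-2-yl in place of 1-methyl-1H-indazol-3-yl gives an at least 8.1-fold lower number from compound 2 to compound 3 (0.91 log units; beyond the scatter). The full size of this step cannot be read because compound 2 is only a limit: the limit of > 16.6 h in this assay, at which 1 of the 3 values shown sits.

The compounds shown do not separate the contribution of the 1,3,4-oxadiazole ring from that of its phenyl. From the compounds shown here alone, a methyl group or a morpholine in place of that phenyl would address this, and whether the same exchange behaves alike on other parts of the series remains open.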